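Amide Replaces Ester at the Carbonyl of Compound 3

The source may report more compounds than this note shows. Statements on the series, on what has been measured and on what is new or still open speak of the compounds shown alone.

Compound 3 `CCCc1nc(CC)c(C(=O)OCC(=O)c2ccccc2)n1Cc1ccc(-c2ccccc2S(=O)(=O)NC(=O)OCCC(C)C)cc1F` stands highest of the three numbers in an assay on isolated protein for binding affinity to Type-2 angiotensin II receptor (Homo sapiens) (on this read-out lower numbers stand for stronger inhibition and higher numbers for weaker inhibition), where compound 3 gives 2 nM. Compound 1 `CCCc1nc(CC)c(C(=O)OCCC[S+]([O-])c2ccccc2)n1Cc1ccc(-c2ccccc2S(=O)(=O)NC(=O)OCCC(C)C)cc1F` gives 1 nM and compound 2 `CCCc1nc(CC)c(C(=O)OCc2ccccc2OC)n1Cc1ccc(-c2ccccc2S(=O)(=O)NC(=O)OCCC(C)C)cc1F` gives 1 nM. The measured steps, no change at the digits printed from compound 1 to compound 2 (within the scatter), a 2.0-fold higher number from compound 1 to compound 3 (0.30 log units; within the scatter) and a 2.0-fold higher number from compound 2 to compound 3 (0.30 log units; within the scatter), all varied the group on the saturated chain carbon bound to an oxygen next to a carbonyl group, and none left the scatter. Compound 4 `CCCc1nc(CC)c(C(=O)NCCCOc2ccccc2)n1Cc1ccc(-c2ccccc2S(=O)(=O)NC(=O)OCCC(C)C)cc1F` differs from compound 3 by (3-phenoxypropyl)amino in place of benzoylmethoxy on a carbonyl carbon. For the measured compounds named here, no measured step exchanges an ester for an amide on this carbonyl carbon, so the three small steps bear only indirectly, as a sign that variation here has been tolerated. Compound 4 is therefore expected to show no step beyond the scatter, a 1.5-fold higher number from compound 3 to compound 4 (0.18 log units; within the scatter). Compound 4 is estimated at 3 nM, between 1 nM and 15 nM.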

Compound 4, half-maximal inhibitory concentration: 9 nM
Compound 4: middle estimate off by 3.0-fold (0.48 log units), on the low side, and the stated range covers the measured number.
By their numbers in this assay, from the lowest: compounds 1, 2 and 3 (each within the scatter of the next); then compound 4.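

For the compounds shown here, replacing the ester on this carbonyl carbon with an amide carrying (3-phenoxypropyl)amino is the first change here to leave the scatter, with a 4.5-fold higher number from compound 3 to compound 4 (0.65 log units; beyond the scatter), a 9.0-fold higher number from compound 2 to compound 4 (0.95 log units; beyond the scatter) and a 9.0-fold higher number from compound 1 to compound 4 (0.95 log units; beyond the scatter). The earlier tolerance of ester side-chain changes therefore did not extend to this exchange. Nothing available explains this loss of binding. The linking atom and the chain changed together, so the compounds leave open which of them carries the step. A (2-methoxybenzyl)amino amide or a 3-phenoxypropyl ester would separate the two.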